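A rearranged side chain on compound 1

The source may report more compounds than this note shows. Statements on the series, on what has been measured and on what is new or still open speak of the compounds shown alone.

Measured in an ADME assay on HepG2 2.2.15 cells (Homo sapiens) for cytotoxicity, read by MTT assay; on this read-out lower numbers stand for higher toxicity in this test and higher numbers for lower toxicity in this test:
- compound 1 `C=C1CC[C@@H]2[C@](C)(COC(=O)/C=C/c3ccccc3)[C@H](O)CC[C@@]2(C)[C@@H]1/C=C/C1=CCOC1=O`: 183000 nM
- compound 2 `C=C1CC[C@@H]2[C@](C)(COC(=O)c3ccc(OC)nc3)[C@H](O)CC[C@@]2(C)[C@@H]1/C=C/C1=CCOC1=O`: 1340000 nM
- compound 3 `C=C1CC[C@@H]2[C@](C)(COC(=O)c3cc(=O)c4ccccc4o3)[C@H](O)CC[C@@]2(C)[C@@H]1/C=C/C1=CCOC1=O`: 171000 nM

Compound 1 sits in the middle of these three numbers, level with compound 3 within the scatter, while compound 2 gives the highest number. The next compound, compound 4 `C=C1CC[C@@H]2[C@](C)(COC(=O)/C=C/c3ccccc3)[C@H](O)CC[C@@]2(C)[C@@H]1C/C=C1\C=COC1=O`, has the same atoms as compound 1, joined differently: a group of 8 heavy atoms (6 carbon, 2 oxygen; one five-membered non-aromatic ring with 1 hetero atom) in place of a group of 8 heavy atoms (6 carbon, 2 oxygen; one five-membered non-aromatic ring with 1 hetero atom), on a saturated ring carbon.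

Two measured steps start from compound 1. One is a 7.3-fold higher number from compound 1 to compound 2 (0.86 log units; beyond the scatter). The other is a 1.1-fold lower number from compound 1 to compound 3 (0.03 log units; within the scatter). A third, a 7.8-fold lower number from compound 2 to compound 3 (0.89 log units; beyond the scatter), links the same pair of replacements. All three swap the group on a carbonyl carbon, so they show how far this assay moved with changes at that site. Among the measured compounds shown here, none of them touches the saturated ring carbon where compound 4 differs, and no measured compound shows a change at that place. These steps therefore give no direction for compound 4. The best anchor is compound 1 with 183000 nM, and the range is kept wide to allow for a move as large as the modest steps seen at the carbonyl carbon.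

The expected result is a 1.1-fold lower number from compound 1 to compound 4 (0.03 log units; within the scatter), so no step beyond the scatter is expected. For compound 4 the estimated value is 170000 nM, with an expected range from 60000 nM to 450000 nM.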

Compound 4, half-maximal cytotoxic concentration: 271000 nM
Estimate against measurement, compound 4: 1.6-fold (0.20 log units) below, and the stated range covers the measured number.
By their numbers in this assay, from the lowest: compounds 3, 1 and 4 (each within the scatter of the next); then compound 2.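

Among the compounds shown here, compound 4 is the first compound here changed on the saturated ring carbon rather than on a carbonyl carbon, and in this assay the outcome is a 1.5-fold higher number from compound 1 to compound 4 (0.17 log units; within the scatter) and so no clear change. The side chain at this place can therefore have its atoms joined differently, with the count of heavy atoms, the five-membered non-aromatic ring and the three double bonds all kept, and the read-out stays within what repeated measurements would give. Nothing available here explains this outcome or says whether the two side chains behave alike in the cells.

This single rearrangement says little about the place as a whole: a side chain of different make-up on the same ring carbon, such as one ending in an amine or a carboxylic acid, or a longer chain, could still move the number much further. For the compounds shown here, it also remains open whether the rearranged side chain would give the same small step with 6-methoxypyridin-3-yl in place of 2-phenylethenyl on the carbonyl carbon, the one change so far that moved the number beyond the scatter from compound 1.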